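This account rests on a few compounds, and the source may have more. Where it says the series, first, only, none or still open, it means among the compounds named here.

Measured compounds:
compound 1, `COc1cc(-n2ncnc2-c2ccc(C)cc2)cc(OC)c1OC`, 250 nM
compound 2, `COc1cc(-c2ncnn2-c2ccc(Cl)cc2Cl)cc(OC)c1OC`, > 10000 nM
compound 3, `COc1cc(-c2ncnn2-c2ccc(Cl)c(Cl)c2)cc(OC)c1OC`, > 10000 nM

All three were tested in a functional assay on HeLa cells (Homo sapiens) for antiproliferative activity, read by MTT assay, with a stated time of 72 h; on this read-out lower numbers stand for stronger inhibition and higher numbers for weaker inhibition. Among the compounds with values here, compound 1 gives 250 nM, the only actual number among the three. Compound 2 gives > 10000 nM, which is a limit of this assay rather than a number. Compound 3 likewise gives > 10000 nM, again a limit. Within the data shown here, the one step between measured compounds, a step that the two limits leave unreadable from compound 2 to compound 3, cannot be read in size, since both values sit at the limit of > 10000 nM in this assay, at which 2 of the 3 values shown sit.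

The unmeasured compound 4, `COc1cc(-n2ncnc2-c2cccc(Cl)c2)cc(OC)c1OC`, follows from compound 1 by 3-chlorophenyl in place of 4-methylphenyl on an aromatic carbon. Among the measured compounds shown here, in compound 2 and compound 3 the halogenated ring sits on a ring nitrogen, not on the aromatic carbon changed here, so the step from compound 2 to compound 3 does not bear on this change, and no measured step shows how this assay responds to it. Compound 4 is therefore expected to lie near compound 1 or somewhat weaker, with wide uncertainty, as a 3.2-fold higher number from compound 1 to compound 4 (0.51 log units; beyond the scatter). The estimate for compound 4 is 800 nM, between 150 nM and 5000 nM.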

Compound 4, half-maximal inhibitory concentration: > 10000 nM
Compound 4: a limit, no number (the forecaster's own chance of this, stated with the estimate: 20%); middle value at least 12-fold (1.09 log units) from the limit.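

In this assay compound 4 gives > 10000 nM, which is a limit of the assay and not a number. At this position on the shared core, the change gives an at least 40-fold higher number from compound 1 to compound 4 (1.60 log units; beyond the scatter), even though 4-methylphenyl and 3-chlorophenyl have the same heavy-atom count and neither has a hydrogen-bond donor or acceptor. This is the first readable step in the series, as the earlier step cannot be read and involves a ring on a ring nitrogen, and compound 4 now shares the same limit: the limit of > 10000 nM in this assay, at which 3 of the 4 values shown sit.

The change alters both the substituent and its place on the phenyl ring, so the compounds shown cannot separate the two. A 4-chlorophenyl or 3-methylphenyl group at this position would be needed to tell whether the chlorine, the move away from the 4-position, or both account for the loss.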